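Removing the Pentyl Group from the Phenol Oxygen

The compounds below may be only part of what the source reports. "The series", "measured", "known", "first", "only" and "open" are said of these compounds alone.

Three members of this flavanone-type series have been tested so far. In a functional assay on HT-29 cells (Homo sapiens) for antiproliferative activity, read by sulforhodamine B assay, with a stated time of 72 h (on this read-out higher numbers stand for weaker inhibition and lower numbers for stronger inhibition), compound 1 `COc1cc(OC(C)=O)c(CC=C(C)C)c2c1C(=O)C[C@@H](c1ccc(OC(C)=O)cc1)O2` gives 32.1 ug/mL. Compound 2 `CCCCCOc1ccc([C@@H]2CC(=O)c3c(OC)cc(OCCCCC)c(CC=C(C)C)c3O2)cc1` gives 8.2 ug/mL in this assay, and compound 3 `COc1ccc([C@@H]2CC(=O)c3c(OC)cc(OC)c(CC=C(C)C)c3O2)cc1` gives 6 ug/mL. Among these three numbers compound 2 stands second highest: its closest neighbour is compound 3, whose number is slightly lower but still within the usual scatter of repeated measurements, so the two cannot be told apart. Compound 1, with a number well above that of compound 2, is the furthest away, and that gap lies beyond the scatter.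

The next compound to be measured is compound 4 `CCCCCOc1cc(OC)c2c(c1CC=C(C)C)O[C@H](c1ccc(O)cc1)CC2=O`. It is obtained from compound 2 by one change: hydrogen in place of pentyl on an oxygen on an aromatic ring. The rest of the molecule, including the pentyl chain on the core and the prenyl side chain, is kept.

Among the measured compounds shown here, no measured pair shows this exact change, so the expected size of the step is uncertain. The step from compound 2 to compound 4 is expected to be small, leaning toward a somewhat higher number, likely within the scatter: a 1.5-fold higher number from compound 2 to compound 4 (0.17 log units; within the scatter). Compound 4 is therefore estimated at 12 ug/mL in this assay, with a range from 4 ug/mL to 35 ug/mL.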

Compound 4, concentration for 50% inhibition: 6.9 ug/mL
Compound 4: the middle estimate sits 1.7-fold (0.24 log units) above what was measured; low and high end bracket the measured number.
By their numbers in this assay, from the lowest: compounds 3, 4 and 2 (each within the scatter of the next); then compound 1.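

In this assay, among the compounds shown here, replacing the pentyl group on this oxygen on an aromatic ring with hydrogen, which turns 4-(pentyloxy)phenyl into 4-hydroxyphenyl, gives a 1.2-fold lower number from compound 2 to compound 4 (0.07 log units; within the scatter) as the first step that can be read at a single place. The pentyl chain and the free hydroxy group therefore cannot be told apart at this position in this read-out, so a group of five carbons can go without a detectable change in the number. Nothing measured here explains why the number holds at this position.

This single step does not show how far that tolerance reaches: a longer chain, a carboxylic acid or an amine carried at the same oxygen could behave quite differently from either pentyl or hydrogen. It also leaves open whether the same swap on the pentyl chain attached to the core would give a similarly small step, since one step at one position cannot be carried over to another.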